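The source may report more compounds than this note shows. Statements on the series, on what has been measured and on what is new or still open speak of the compounds shown alone.

Going by the values given here, in a functional assay on A549 cells (Homo sapiens) for cytotoxicity, read by MTT assay, with a stated time of 72 h (on this read-out lower numbers stand for stronger inhibition and higher numbers for weaker inhibition), compound 1 `COc1ccc(/C=N/NC(=O)Nc2ccc(Oc3ccnc(-c4nncn4CCN(C)C)c3)c(F)c2)c(OC)c1` gives 2820 nM, the only plain number among the two values shown. Compound 2 `CN(C)CCn1cnnc1-c1cc(Oc2ccc(NC(=O)N/N=C/c3cc(Br)c(O)c(Br)c3)cc2F)ccn1` reaches only a limit of the assay, > 100000 nM. Among the compounds with values here, the single measured step, an at least 35-fold higher number from compound 1 to compound 2 (1.54 log units; beyond the scatter), is anchored by the limit of > 100000 nM in this assay, at which 1 of the 2 values shown sits, and so is a lower bound on the loss. Compound 3 `Cc1cc(/C=N/NC(=O)Nc2ccc(Oc3ccnc(-c4nncn4CCN(C)C)c3)c(F)c2)cc(C)c1O` carries the change (4-hydroxy-3,5-dimethylphenyl in place of 2,4-dimethoxyphenyl on a carbon with a double bond to nitrogen). Like the 3,5-dibromo-4-hydroxyphenyl of compound 2, the entering 4-hydroxy-3,5-dimethylphenyl is a hydroxyphenyl, so a large loss is expected because an at least 35-fold higher number from compound 1 to compound 2 (1.54 log units; beyond the scatter) was large, with a real chance of another limit. The expected step is a 14-fold higher number from compound 1 to compound 3 (1.15 log units; beyond the scatter). Compound 3 is estimated at 40000 nM, between 8000 nM and 200000 nM.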

Compound 3, half-maximal inhibitory concentration: 1640 nM
Estimate against measurement, compound 3: 24-fold (1.39 log units) above; the measured number lies below the stated range.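

A hydroxyphenyl on this carbon does not in itself bring a loss in this assay: 4-hydroxy-3,5-dimethylphenyl in place of 2,4-dimethoxyphenyl gives a 1.7-fold lower number from compound 1 to compound 3 (0.24 log units; within the scatter). Among these three compounds the loss stays with the 3,5-dibromo-4-hydroxyphenyl of compound 2, and replacing that group with 4-hydroxy-3,5-dimethylphenyl gives an at least 60-fold lower number from compound 2 to compound 3 (1.78 log units; beyond the scatter). The size of that step is only a bound, since one end of it is a limit: the limit of > 100000 nM in this assay, at which 1 of the 3 values shown sits.

Going by these compounds, whether a single bromine on the hydroxyphenyl is enough for the loss remains open. So does the response on this carbon to a more distinct aryl group, such as an aminophenyl or a carboxyphenyl.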